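This account rests on a few compounds, and the source may have more. Where it says the series, first, only, none or still open, it means among the compounds named here.

Compound 1 `O=S(=O)(CC1=NCCO1)C1C(c2ccc(Cl)cc2)=NN(c2ccccc2)C1c1ccc(Cl)cc1` gives "not active" (no number reported) in a functional assay, read by Griess assay, with a stated time of 150 min, tested at 100 ug/mL (on this read-out lower numbers stand for a weaker effect and higher numbers for a stronger effect at the one concentration tested), and compound 2 `COc1ccc(-c2noc(-c3ccc(C)cc3)c2S(=O)(=O)CC2=NCCS2)cc1` gives "not active" (no number reported) in this assay, with no number reported for either; compound 3 `Cc1ccc(C2CNN=C2S(=O)(=O)CC2=NCCO2)cc1` gives 51.4% in this assay. Compound 2 therefore stands without a single number, alongside one further entry that also lacks one. Compound 4 `COc1ccc(-c2noc(-c3ccc(C)cc3)c2S(=O)(=O)CC2=NCCO2)cc1` differs from compound 2 by a group of 5 heavy atoms (3 carbon, 1 nitrogen, 1 oxygen; one five-membered non-aromatic ring with 2 hetero atoms) in place of a group of 5 heavy atoms (3 carbon, 1 nitrogen, 1 sulfur; one five-membered non-aromatic ring with 2 hetero atoms), on a saturated chain carbon bound to a sulfonyl sulfur. Going by the values given here, no measured pair carrying this change exists, so the size and direction of the step in this assay cannot be read from the data; compound 3 holds the entering group but on a different core, while compound 2 shows no activity at the tested concentration. Compound 4 is expected to stay weak, estimated near 15%, within 0% to 45%, with a real chance of another report without a number.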

Compound 4, a percentage reported as activity, at one concentration (the size of the read-out at that concentration, not a potency): 76.2%
Beside the measured number, compound 4's estimate is 61.2 percentage points below it; the measured number lies above the stated range.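

Going by these compounds alone, compound 2 is reported without a number, so no step to compound 4 can be read. Nothing on hand explains the result. The compounds shown leave open how large the change from the sulfur-containing ring to the oxygen-containing ring is on any shared core.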